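This account rests on a few compounds, and the source may have more. Where it says the series, first, only, none or still open, it means among the compounds named here.

Compound 1 `Cc1ccc(NC(=O)Cn2cc(COc3ccc4c(c3)CCC4)nn2)cc1`, compound 2 `COc1ccccc1-n1cc(COc2ccc3c(c2)CCC3)nn1`, compound 3 `Cc1ccccc1NC(=O)Cn1cc(COc2ccc3c(c2)CCC3)nn1` and compound 4 `COc1ccccc1NC(=O)Cn1cc(COc2ccc3c(c2)CCC3)nn1` share a common core and differ in the group attached to it. In an ADME assay on HEK293 cells (Homo sapiens) for inhibition, read by MTT assay, with a stated time of 48 h, tested at 25 uM (a higher number here means more inhibition at the concentration tested (going by the name of the read-out), a lower number less inhibition), compound 2 gives 19.8%. For compound 1 the same assay shows "not determined" (no result reported), and for compound 3 it likewise shows "not determined" (no result reported), so compound 3 stands without a single number, as does one further compound in this set. Compound 4 differs from compound 3 by methoxy in place of methyl on an aromatic carbon; the group sits on an aromatic carbon of a six-membered aromatic ring of carbon only, ortho to a large group. Among the compounds with values here, no measured pair in this set isolates such a change, so the size of the step in this assay cannot be read from the data; the only number at hand, that of compound 2, is modest, and no step beyond the scatter is anticipated from it. Compound 4 is therefore expected to give about 20%, with a range from 2% to 45%.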

Compound 4, a percentage reported as inhibition, at one concentration (the size of the read-out at that concentration, not a potency): 23.4%
Compound 4: the middle estimate sits 3.4 percentage points below what was measured; the range from low to high includes it.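

No step can be read between compound 3, which shows "not determined" (no result reported) in this assay, and compound 4, which gives 23.4%. The compounds shown leave open what methoxy in place of methyl does to this read-out. No supporting evidence bears on this result.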